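This account rests on a few compounds, and the source may have more. Where it says the series, first, only, none or still open, it means among the compounds named here.

Compounds measured in a functional assay on HCT-116 cells (Homo sapiens) for cytotoxicity, read by MTT assay, with a stated time of 48 h; on this read-out lower numbers stand for stronger inhibition and higher numbers for weaker inhibition:

Compound 1, `CNC(=O)c1ccc(Sc2ccc(NC(=S)Nc3cccc(C(F)(F)F)c3)cc2)nc1`, gives 25900 nM.
Compound 2, `CNC(=O)c1ccc(Sc2ccc(NC(=S)Nc3cccc(C)c3)cc2)nc1`, gives 52400 nM.
Compound 3, `CNC(=O)c1ccc(Sc2cccc(NC(=S)Nc3ccc(F)c(Cl)c3)c2)nc1`, gives 17300 nM.

Compound 3 gives the lowest of the three numbers. Its nearest neighbour is compound 1, whose number is higher by a margin that lies within the scatter, so the two cannot be ordered; compound 2 stands further off, beyond the scatter. Among the compounds with values here, the one measured step, a 2.0-fold higher number from compound 1 to compound 2 (0.31 log units; beyond the scatter), concerns a change at the far aromatic ring of the thiourea and is modest.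

Compound 4, `CNC(=O)c1ccc(Sc2cccc(NC(=S)Nc3ccc(F)c(F)c3)c2)nc1`, is not yet measured. It differs from compound 3 in one place: fluoro in place of chloro on an aromatic carbon. Within the data shown here, no measured pair covers a swap of one halogen for another on that ring; the step from compound 1 to compound 2 concerns a different kind of group and offers only a general sense of scale, and that scale was modest. On this basis the expectation for compound 4 is a step in this assay that stays within the scatter, a 1.3-fold higher number from compound 3 to compound 4 (0.10 log units; within the scatter), perhaps leaning toward a slightly higher number. The estimate for compound 4 is therefore 22000 nM, with a range from 9000 nM to 55000 nM.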

Compound 4, half-maximal inhibitory concentration: 35100 nM
Compound 4: the middle estimate sits 1.6-fold (0.20 log units) below what was measured, and the stated range covers the measured number.
By their numbers in this assay, from the lowest: compounds 3, 1, 4 and 2 (each within the scatter of the next, the first and the last beyond it).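

In this assay, within the data shown here, the exchange from 3-chloro-4-fluorophenyl to 3,4-difluorophenyl gives the first measured halogen swap, and it is a 2.0-fold higher number from compound 3 to compound 4 (0.31 log units; beyond the scatter), a step of the same printed size as a 2.0-fold higher number from compound 1 to compound 2 (0.31 log units; beyond the scatter) on the other ring pattern. This position, ortho to a fluoro group and meta to a large group, therefore responds measurably to the exchange of a single heavy atom, even though the swap leaves the counts of hydrogen-bond donors and acceptors and the net charge unchanged. Nothing measured here accounts for the direction or size of this step.

Going by these compounds, what a bromo group, a methoxy group, a nitrile or a plain hydrogen would give at this same position remains open, so two halogens are all that can be set side by side here. On these data alone, it also remains open whether the same exchange of chloro for fluoro would give a similar step on the ring pattern of compound 1, or in cells other than those of this assay as used here.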